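Phenyl in Place of Methyl: Expectation for Compound 4

This account rests on a few compounds, and the source may have more. Where it says the series, first, only, none or still open, it means among the compounds named here.

In an assay on HL-60 cells for inhibition of glutathione S-transferase P (Homo sapiens) (on this read-out lower numbers stand for stronger inhibition and higher numbers for weaker inhibition), compound 1 `C=C(C)C(=O)c1ccc(OCc2nc(C)no2)cc1C` gives 5000 nM.
In this assay compound 2 `C=C(C)C(=O)c1ccc(OCc2nc(-c3ccccc3)no2)cc1C` gives 1970 nM.
In this assay compound 3 `C=C(C)C(=O)c1ccc(OCc2nc(C)no2)c(C)c1C` gives 4000 nM.

Compound 3 sits close to compound 1, the step of a 1.3-fold lower number from compound 1 to compound 3 (0.10 log units; within the scatter) lying within the scatter, while compound 2 shows a clearly lower number than compound 3. Compound 4 `C=C(C)C(=O)c1ccc(OCc2nc(-c3ccccc3)no2)c(C)c1C` differs from compound 3 by phenyl in place of methyl on an aromatic carbon. The same exchange has been measured once, as a 2.5-fold lower number from compound 1 to compound 2 (0.40 log units; beyond the scatter), a modest but real gain. Within the data shown here, that single step is the only evidence bearing on compound 4, so a gain of similar size is expected in this assay, as a 2.5-fold lower number from compound 3 to compound 4 (0.40 log units; beyond the scatter). Compound 4 is therefore estimated at 1600 nM, with a likely range from 800 nM to 3200 nM.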

Compound 4, half-maximal inhibitory concentration: 1800 nM
Compound 4: the middle estimate sits 1.1-fold (0.05 log units) below what was measured; the measured number falls inside the stated range.
By their numbers in this assay, from the lowest: compounds 4 and 2 (each within the scatter of the next); then compounds 3 and 1 (each within the scatter of the next).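

Phenyl in place of methyl on the five-membered aromatic ring lowers the number a second time in this assay, a 2.2-fold lower number from compound 3 to compound 4 (0.35 log units; beyond the scatter), so the gain is no longer tied to a single core: the same change on two cores in this assay, a 2.5-fold lower number (0.40 log units; beyond the scatter) from compound 1 to compound 2 and a 2.2-fold lower number (0.35 log units; beyond the scatter) from compound 3 to compound 4, 1.1-fold (0.06 log units) apart, within the scatter of two such steps. The extra methyl on the shared core, a 1.1-fold lower number from compound 2 to compound 4 (0.04 log units; within the scatter), stays within the scatter, as it did without the phenyl: the same change on two cores in this assay, a 1.3-fold lower number (0.10 log units; within the scatter) from compound 1 to compound 3 and a 1.1-fold lower number (0.04 log units; within the scatter) from compound 2 to compound 4, 1.1-fold (0.06 log units) apart, within the scatter of two such steps.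

The compounds shown leave open how an amine or a longer chain at this position would read in this assay. As far as these compounds go, whether a phenyl carrying a further group would lower the number again is also open.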